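A few compounds are considered here, and "the series" means these few. Any claim that something is new, unique, unknown or untested is made for them only; others in the source may bear on it.

Compound 2, whose structure is `CCCCCCCCCCCCCCCCCCNC(=O)[C@@H]1CSC(c2ccc(OCC)cc2)N1`, is known in a functional assay on DU-145 cells (Homo sapiens) for antiproliferative activity, read by sulforhodamine B assay (on this read-out lower numbers stand for stronger inhibition and higher numbers for weaker inhibition), only through a limit: in this assay compound 2 gives > 20000 nM, a limit of the assay rather than a number. For the measured compounds named here, the one measured neighbour of compound 2 is compound 1, with the structure `CCCCCCCCCCCCCCCCCCNC(=O)[C@@H]1CSC(c2ccc(N(C)C)cc2)N1`; in this assay compound 1 gives 5300 nM. The step from these two values is an at least 3.7-fold higher number from compound 1 to compound 2 (0.57 log units; beyond the scatter), brought about by ethoxy in place of dimethylamino on an aromatic carbon. Its true size is open because of the limit of > 20000 nM in this assay, at which 1 of the 2 values shown sits.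

Compound 3 has the structure `CCCCCCCCCCCCCCCCCCNC(=O)[C@@H]1CSC(c2c(OC)cc(OC)cc2OC)N1` and differs from compound 2 by 2,4,6-trimethoxyphenyl in place of 4-ethoxyphenyl on a saturated ring carbon. Going by the values given here, the single measured step bears on it only loosely: it shows that exchanging the substituent on this aromatic ring can move this assay by a modest amount, but it says nothing about the direction a trimethoxy pattern would take. With compound 2 resting at a limit, the account therefore expects compound 3 to stay in the weak range, and the expected step from compound 2 to compound 3 is an at least 1.3-fold lower number from compound 2 to compound 3 (0.12 log units; that floor lies within the scatter). The estimate for compound 3 in this assay is 15000 nM, within a range from 4000 nM to 40000 nM.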

Compound 3, half-maximal inhibitory concentration: 7300 nM
Estimate against measurement, compound 3: 2.1-fold (0.31 log units) above; the measured number falls inside the stated range.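

In this assay, 2,4,6-trimethoxyphenyl in place of 4-ethoxyphenyl on this saturated ring carbon gives an at least 2.7-fold lower number from compound 2 to compound 3 (0.43 log units; beyond the scatter), so a group without the dimethylamino substituent of compound 1 can also give a measured number here rather than a limit. The comparison with compound 1 gives a 1.4-fold higher number from compound 1 to compound 3 (0.14 log units; within the scatter), and the 2,4,6-trimethoxyphenyl and 4-(dimethylamino)phenyl groups therefore cannot be told apart at this position in this assay. The change from compound 2 to compound 3 has a floor but no upper bound, and its true size stays open because one end of the step is a limit, not a number: the limit of > 20000 nM in this assay, at which 1 of the 3 values shown sits.

The compounds shown leave open how a phenyl ring carrying a single methoxy group or two methoxy groups would compare on the same ring carbon, so the effect of the 2,4,6-trimethoxyphenyl group cannot yet be divided among its three methoxy groups. As far as these compounds go, it also remains open whether the same order of results would hold with a shorter chain on the amide, or with a carboxylic acid in place of the amide.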